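Three Aryl Groups Measured, a Fourth Still to Come

The source may hold more compounds than are shown below. What is called first, only, known or untested is meant among the compounds shown, and "the series" means these compounds.

Compound 1 `CC(=O)Nc1cccc(C2CCN(CCCn3c(-c4ccccc4C(F)(F)F)nc4ccccc43)CC2)c1` gives 50 nM in an assay for displacement of a labelled ligand from melanin-concentrating hormone receptor 1 (Homo sapiens), read by fluorescence; a lower number here means a stronger inhibitor, a higher number a weaker inhibitor. Compound 2 `CC(=O)Nc1cccc(C2CCN(CCCn3c(-c4ccc(C#N)cc4)nc4ccccc43)CC2)c1` gives 16 nM. Compound 3 `CC(=O)Nc1cccc(C2CCN(CCCn3c(-c4ccc(Cl)c(Cl)c4)nc4ccccc43)CC2)c1` gives 24 nM.

All three compounds share one core and differ only in the aryl group attached to it. Compound 3 stands second highest of the three numbers: its nearest neighbour is compound 2, with a 1.5-fold higher number from compound 2 to compound 3 (0.18 log units; within the scatter), while its furthest is compound 1, with a 2.1-fold lower number from compound 1 to compound 3 (0.32 log units; beyond the scatter). Compound 2 and compound 1 are separated by a 3.1-fold lower number from compound 1 to compound 2 (0.49 log units; beyond the scatter).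

Compound 4 `CC(=O)Nc1cccc(C2CCN(CCCn3c(-c4ccc(Cl)cc4F)nc4ccccc43)CC2)c1` has not yet been measured. It carries 4-chloro-2-fluorophenyl in place of 3,4-dichlorophenyl on an aromatic carbon. Within the data shown here, two measured steps bear on this change, since both alter the same aryl group on the same carbon: the move from compound 1 to compound 3 gave a 2.1-fold lower number from compound 1 to compound 3 (0.32 log units; beyond the scatter), and the move from compound 2 to compound 3 gave a 1.5-fold higher number from compound 2 to compound 3 (0.18 log units; within the scatter). Across these three aryl groups the numbers stay within a narrow band, so the new aryl group is expected to land in a similar range, with at most a modest step in either direction. The estimate for compound 4 is 30 nM, with a range from 12 nM to 80 nM. This corresponds to an expected step of a 1.3-fold higher number from compound 3 to compound 4 (0.10 log units; within the scatter).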

Compound 4, half-maximal inhibitory concentration: 1 nM
Beside the measured number, compound 4's estimate is 30-fold (1.48 log units) above it; the measured number lies below the stated range.
By their numbers in this assay, from the lowest: compound 4; then compounds 2 and 3 (each within the scatter of the next); then compound 1.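

The three earlier aryl groups sat in a narrow band and gave no sign that this carbon, between two ring nitrogen atoms, could produce a large change in this assay. With a 24-fold lower number from compound 3 to compound 4 (1.38 log units; beyond the scatter) and a 16-fold lower number from compound 2 to compound 4 (1.20 log units; beyond the scatter) and a 50-fold lower number from compound 1 to compound 4 (1.70 log units; beyond the scatter) as the new steps, compound 4 has the lowest number of the four, even though 3,4-dichlorophenyl and 4-chloro-2-fluorophenyl have the same count of heavy atoms, and neither has hydrogen-bond donors, hydrogen-bond acceptors or a net charge. A substituent numbered 2 on the phenyl ring is not enough on its own, as compound 1 also has one, in its 2-(trifluoromethyl)phenyl group, yet has the highest number; nothing given here explains why the number falls so far.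

Still open, as far as these compounds go, is which feature of the new group matters, the fluorine, the chlorine or the two together, and a plain 4-chlorophenyl or 2-fluorophenyl group at this carbon would help separate them. From the compounds shown here alone, it is also open whether a 2,4-difluorophenyl group, or an aryl ring bearing an amine, would keep the number this low.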